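Removing one N-methyl from compound 2

The source may report more compounds than this note shows. Statements on the series, on what has been measured and on what is new or still open speak of the compounds shown alone.

Measured compounds:
compound 1, `C#Cc1cn([C@@H]2O[C@H](CO)[C@@H](O)[C@H]2O)c2ncnc(C)c12`: 110 nM
compound 2, `C#Cc1cn([C@@H]2O[C@H](CO)[C@@H](O)[C@H]2O)c2ncnc(N(C)C)c12`: 260 nM

In a functional assay on K562 cells (Homo sapiens), read by MTT assay, with a stated time of 72 h (on this read-out higher numbers stand for weaker inhibition and lower numbers for stronger inhibition), compound 1 gives 110 nM and compound 2 gives 260 nM. Going by the values given here, compound 2 therefore stands highest of the two numbers, its nearest neighbour being compound 1, and the one recorded step, a 2.4-fold higher number from compound 1 to compound 2 (0.37 log units; beyond the scatter), is modest.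

Compound 3, `C#Cc1cn([C@@H]2O[C@H](CO)[C@@H](O)[C@H]2O)c2ncnc(NC)c12`, differs from compound 2 by hydrogen in place of methyl on a nitrogen on an aromatic ring. Among the compounds with values here, no measured step bears directly on this change: the single step, a 2.4-fold higher number from compound 1 to compound 2 (0.37 log units; beyond the scatter), runs from methyl to dimethylamino, not from dimethylamino to methylamino. Since compound 1 and compound 2 sit close together, the change is expected to move the number at most modestly, in either direction, and probably not far beyond the scatter.

Compound 3 is therefore estimated at 190 nM in this assay, with a range from 70 nM to 500 nM, a step of a 1.4-fold lower number from compound 2 to compound 3 (0.14 log units; within the scatter).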

Compound 3, half-maximal inhibitory concentration: 1380 nM
Compound 3: the middle estimate sits 7.3-fold (0.86 log units) below what was measured, outside the stated range (above it).
By their numbers in this assay, from the lowest: compound 1; then compound 2; then compound 3.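

In this assay the single methyl on the nitrogen turns out to matter: hydrogen in place of methyl on a nitrogen on an aromatic ring gives a 5.3-fold higher number from compound 2 to compound 3 (0.72 log units; beyond the scatter), so dimethylamino and methylamino cannot be treated as interchangeable here. Set against the methyl group on the aromatic carbon, methylamino gives a 13-fold higher number from compound 1 to compound 3 (1.10 log units; beyond the scatter), the largest step in the series, which shows that this position can separate the compounds far more widely than the first step suggested. Nothing available explains why removing this one methyl has such an effect.

The compounds shown leave open whether the unsubstituted amine would fall nearer to compound 2 or to compound 3. They also leave open how a longer chain such as ethylamino, or a ring such as pyrrolidine, would read at this nitrogen.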